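Exchanging the sulfur substituent: compound 3 to compound 4

A few compounds are considered here, and "the series" means these few. Any claim that something is new, unique, unknown or untested is made for them only; others in the source may bear on it.

Three compounds have numbers in a functional assay on DU-145 cells (Homo sapiens) for inhibition, read by trypan blue exclusion, with a stated time of 96 h; a higher number here means a weaker inhibitor of growth, a lower number a stronger inhibitor of growth. Compound 1 (`O=C(/C(=C\c1ccc(O)cc1)SCc1ccc(Cl)cc1)c1ccc(Br)cc1`) gives 10000 nM, compound 2 (`COc1ccc(/C=C(/SCc2ccc(Cl)cc2)C(=O)c2ccc(Br)cc2)cc1`) gives 10000 nM, and compound 3 (`COc1ccccc1/C=C(/Sc1ccc(C)cc1)C(=O)c1ccc(Br)cc1`) gives 9000 nM, which lies within the scatter of both others.

The next structure is compound 4 (`COc1ccccc1/C=C(/SCc1ccc(Cl)cc1)C(=O)c1ccc(Br)cc1`), with 4-chlorobenzyl in place of 4-methylphenyl on a sulfur.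

Going by the values given here, no measured step makes this exchange directly. Among the compounds with values here, the only measured step, no change at the digits printed from compound 1 to compound 2 (within the scatter), is methyl in place of hydrogen on an oxygen on an aromatic ring, at a different place, and it stays within the scatter. The indirect evidence is that compound 2, which already carries 4-chlorobenzyl on sulfur, gives 10000 nM, within the scatter of compound 3 at 9000 nM. Nothing here points to a shift in either direction. The expected change is no change at the digits printed from compound 3 to compound 4 (within the scatter), no larger than the scatter. For compound 4 the estimated value is 9000 nM, with an expected range from 4000 nM to 18000 nM.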

Compound 4, concentration for 50% growth inhibition: 1000 nM
The estimate for compound 4 lay 9.0-fold (0.95 log units) above the measured number; measured number below the stated range.
By their numbers in this assay, from the lowest: compound 4; then compounds 3, 1 and 2 (each within the scatter of the next).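

In this assay the group on sulfur proves able to move the number: with the 2-methoxyphenyl held constant, 4-chlorobenzyl in place of 4-methylphenyl gives (a 9.0-fold lower number from compound 3 to compound 4 (0.95 log units; beyond the scatter)). 4-Chlorobenzyl does not carry this gain on its own, since it is also present in the two compounds with a group in the 4-position of the aryl ring, and 2-methoxyphenyl in place of those groups gives (a 10-fold lower number from compound 2 to compound 4 (1.00 log units; beyond the scatter)) and (a 10-fold lower number from compound 1 to compound 4 (1.00 log units; beyond the scatter)), so among these four compounds the lower number appears only where both groups occur together. No available evidence accounts for this combination.

On these data alone, it remains open whether the lower number survives an amine or a carboxylic acid on the benzyl ring. As far as these compounds go, a longer chain between the sulfur and that ring is equally open.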